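Nitro in place of amino: outlook for compound 3

A few compounds are considered here, and "the series" means these few. Any claim that something is new, unique, unknown or untested is made for them only; others in the source may bear on it.

Compound 1 `Nc1ccc2c(c1)/C(=C1\C(=O)Nc3ccccc31)C(=O)N2` stands at the boundary of what the assay can report: in a functional assay on Huh-7 cells (Homo sapiens) for antiproliferative activity, with a stated time of 72 h (a higher number here means a weaker inhibitor, a lower number a stronger inhibitor), compound 1 gives > 25000 nM, a limit rather than a number. Compound 2 `O=C1Nc2cc([N+](=O)[O-])ccc2/C1=C1/Nc2ccccc2C1=O` also gives > 25000 nM in this assay, again a limit. Both values shown sit at the limit (the limit of > 25000 nM in this assay, at which 2 of the 2 values shown sit), so compound 1 cannot be ranked within the pair. Compound 3 `O=C1Nc2ccccc2/C1=C1\C(=O)Nc2ccc([N+](=O)[O-])cc21` differs from compound 1 by nitro in place of amino on an aromatic carbon. Going by the values given here, no measured step covers this change; the expected step of a number no higher from compound 1 to compound 3 (the limit leaves the size open) is none beyond the scatter. Compound 3 is accordingly expected at 25000 nM, with a range of 10000 nM to 60000 nM.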

Compound 3, half-maximal inhibitory concentration: > 25000 nM
Compound 3 was reported as a limit; the forecaster's own chance of this, stated with the estimate: 80%; the middle value sits exactly at the limit.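

No step from compound 1 to compound 3 can be read, because both stand at a limit in this assay: the limit of > 25000 nM in this assay, at which 3 of the 3 values shown sit.

The compounds shown leave open what nitro in place of amino on an aromatic carbon does to potency, and how compound 1, compound 2 and compound 3 rank.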